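Swapping a Methyl for a Chloro: From Compound 1 to 4

This account rests on a few compounds, and the source may have more. Where it says the series, first, only, none or still open, it means among the compounds named here.

Compound 1 `Cc1ccc(-c2nc3cccnc3o2)cc1` was tested in a functional assay on the whole organism for inhibition, with Rattus norvegicus as the target, at a dose of 30 mg/kg (a lower number here means less inhibition, a higher number more inhibition at the dose given (going by the name of the read-out)), where compound 1 gives 0%. That is the lowest of the three numbers gathered so far. Compound 3 `N#Cc1cccc(C#N)c1-c1nc2ncccc2o1` gives 19%, and compound 2 `Brc1cccc(-c2nc3ncccc3o2)c1` gives 23%; both stand above compound 1 by more than the usual scatter. Compound 4 `Clc1ccc(-c2nc3cccnc3o2)cc1` has not yet been tested. It differs from compound 1 in one place: chloro in place of methyl on an aromatic carbon. Among the measured compounds shown here, no measured pair shows this particular change, so its effect can only be estimated. The expected step is a number 10 percentage points higher from compound 1 to compound 4 (within the scatter), a shift that is expected to stay close to the scatter. Compound 4 is therefore estimated to give 10%, with a range from 0% to 30%.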

Compound 4, a percentage reported as inhibition, in the whole organism at one dose (the size of the read-out at that dose, not a potency): 14%
Beside the measured number, compound 4's estimate is 4 percentage points below it; measured number inside the range.
By their numbers in this assay, from the lowest: compound 1; then compounds 4, 3 and 2 (each within the scatter of the next).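

Chloro in place of methyl, on an aromatic carbon para to a group of 9 heavy atoms, gives a number 14 percentage points higher from compound 1 to compound 4 (beyond the scatter) in this assay. Among the compounds shown here, this is the first pair differing in one place, and it shows that a single-atom swap at this position can move the number beyond the scatter. Nothing measured here bears on why the number moves.

On these data alone, what an amine, a carboxylic acid or a longer chain would do at this position remains open.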